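A few compounds are considered here, and "the series" means these few. Any claim that something is new, unique, unknown or untested is made for them only; others in the source may bear on it.

Compound 1 `CCCOC(=O)N1N=C(c2cccc(OC)c2)CC1c1cc(OC)c(OC)c(OC)c1` carries a propoxycarbonyl group on the shared core. In a functional assay on HepG2 cells (Homo sapiens) for antiproliferative activity, read by MTT assay, with a stated time of 48 h (a lower number here means a stronger inhibitor of growth, a higher number a weaker inhibitor of growth), compound 1 gives only a limit, > 10000 nM. Compound 2 `COc1cccc(C2=NN(C(=O)OCc3ccccc3)C(c3cc(OC)c(OC)c(OC)c3)C2)c1` likewise gives a limit in this assay, > 10000 nM. Compound 3 `CCCOC(=O)N1N=C(c2ccc(OC)cc2)CC1c1cc(OC)c(OC)c(OC)c1` also gives a limit in this assay, > 10000 nM. The change phenyl in place of ethyl on a saturated chain carbon bound to an oxygen next to a carbonyl group yields a step that the two limits leave unreadable from compound 1 to compound 2, since (the limit of > 10000 nM in this assay, at which 3 of the 3 values shown sit). The cores of compound 1 and compound 3 differ by 4-methoxyphenyl in place of 3-methoxyphenyl on a carbon with a double bond to nitrogen, which gives a step that the two limits leave unreadable from compound 1 to compound 3. Compound 4 `COc1ccc(C2=NN(C(=O)OCc3ccccc3)C(c3cc(OC)c(OC)c(OC)c3)C2)cc1` differs from compound 3 by phenyl in place of ethyl on a saturated chain carbon bound to an oxygen next to a carbonyl group, the same change as from compound 1 to compound 2, at the same place. For compound 4 the expected step is a step that the limit leaves unreadable from compound 3 to compound 4 in this assay; this rests on a step that the two limits leave unreadable from compound 1 to compound 2 and on (the limit of > 10000 nM in this assay, at which 3 of the 3 values shown sit). Compound 4 is therefore estimated at 20000 nM in this assay, between 8000 nM and 60000 nM, most likely again reported as a limit.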

Compound 4, concentration for 50% growth inhibition: > 10000 nM
Compound 4: a limit, no number; the forecaster's own chance of this, stated with the estimate: 80%; the middle value is on the limit's open side.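

Compound 4 also gives only a limit in this assay, so neither the step from compound 3 nor the step from compound 2 to compound 4 can be read: the limit of > 10000 nM in this assay, at which 4 of the 4 values shown sit.

The compounds shown leave open whether any change on the shared core yields a measurable growth-inhibition value.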